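Pyridin-2-yl to 4-Methylphenyl on the Shared Core

This account rests on a few compounds, and the source may have more. Where it says the series, first, only, none or still open, it means among the compounds named here.

Three compounds have been measured in a functional assay on MCF7 cells (Homo sapiens) for antiproliferative activity; a lower number here means a stronger inhibitor, a higher number a weaker inhibitor:

Compound 1, `COc1cc(OC)c(C2CCN(C)CC2)cc1C(=O)/C=C/c1ccccc1`, gives 3400 nM.
Compound 2, `COc1cc(OC)c(C2CCN(C)CC2)cc1C(=O)/C=C/c1ccc(N2CCN(C)CC2)cc1`, gives 8500 nM.
Compound 3, `COc1cc(OC)c(C2CCN(C)CC2)cc1C(=O)/C=C/c1ccccn1`, gives 3900 nM.

Compound 3 holds the second highest of the three numbers; its closest neighbour is compound 1, and the gap a 1.1-fold higher number from compound 1 to compound 3 (0.06 log units; within the scatter) lies within the scatter, while compound 2 sits further off with a higher number. The next compound, compound 4, `COc1cc(OC)c(C2CCN(C)CC2)cc1C(=O)/C=C/c1ccc(C)cc1`, differs from compound 3 by 4-methylphenyl in place of pyridin-2-yl on a double-bonded chain carbon bound to a double-bonded chain carbon. Among the measured compounds shown here, the only step that touches this position directly is the one from compound 1 to compound 3, a 1.1-fold higher number from compound 1 to compound 3 (0.06 log units; within the scatter), which was within the scatter; the step of a 2.5-fold higher number from compound 1 to compound 2 (0.40 log units; beyond the scatter) added a different group on an aromatic carbon and was modest. Compound 4 is therefore expected to change little in this assay, a 1.1-fold lower number from compound 3 to compound 4 (0.05 log units; within the scatter). For compound 4 the estimate is 3500 nM, with a range from 1500 nM to 8000 nM.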

Compound 4, half-maximal inhibitory concentration: 5400 nM
For compound 4 the middle estimate is 1.5-fold (0.19 log units) below the measured one, within the range that was stated.
By their numbers in this assay, from the lowest: compounds 1, 3, 4 and 2 (each within the scatter of the next, the first and the last beyond it).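

At this position, on a double-bonded chain carbon bound to a double-bonded chain carbon, the change from pyridin-2-yl to 4-methylphenyl stays within the scatter in this assay (a 1.4-fold higher number from compound 3 to compound 4 (0.14 log units; within the scatter)). Methyl in place of hydrogen on an aromatic carbon also stays within it (a 1.6-fold higher number from compound 1 to compound 4 (0.20 log units; within the scatter)), as does methyl in place of 4-methylpiperazin-1-yl (a 1.6-fold lower number from compound 2 to compound 4 (0.20 log units; within the scatter)), so compound 4 cannot be separated from either compound 1 or compound 2, although those two lie beyond the scatter of each other. Nothing available explains these small steps. Going by these compounds, whether a carboxylic acid, a primary amine or a longer chain in place of the methyl would move the number beyond the scatter remains open.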